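The compounds below may be only part of what the source reports. "The series", "measured", "known", "first", "only" and "open" are said of these compounds alone.

Compound 2 `Cc1ccccc1Oc1ccc(N2C[C@@H](C(F)(F)F)C[C@H]2CC(=O)O)cc1` is the anchor here: in a functional assay on cells for agonist activity at Free fatty acid receptor 1 (Mus musculus), read by FLIPR and calcium flux, with a stated time of 100 s (on this read-out lower numbers stand for an effect already at smaller amounts and higher numbers for an effect only at larger amounts of compound), compound 2 gives 330 nM, the only true number among the three results shown. Compound 1 `O=C(O)C1CCN(c2ccc(OCc3ccc(Cl)cc3Cl)cc2)C1` reaches only a limit of this assay, > 16000 nM (the limit of > 16000 nM in this assay, at which 1 of the 3 values shown sits). Compound 3 `Cc1ccccc1COc1ccc(N2CCC[C@H]2CC(=O)O)cc1C` likewise stops at a limit, > 33000 nM (the limit of > 33000 nM in this assay, at which 1 of the 3 values shown sits). Compound 4 `Cc1ccccc1Oc1ccc(N2CCC[C@H]2CC(=O)O)cc1` differs from compound 2 by hydrogen in place of trifluoromethyl on a saturated ring carbon. Going by the values given here, no pair of measured compounds differs in a single place, so the size of such a change cannot be read from these data. The expected step of a 4.5-fold higher number from compound 2 to compound 4 (0.66 log units; beyond the scatter) is a moderate loss, somewhat beyond the scatter. Compound 4 is estimated at 1500 nM, with a range from 300 nM to 8000 nM.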

Compound 4, half-maximal effective concentration: 5600 nM
For compound 4 the middle estimate is 3.7-fold (0.57 log units) below the measured one; the measured number falls inside the stated range.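

Going by these compounds alone, compound 4 gives the first comparison of a single change in this set: in this assay hydrogen in place of trifluoromethyl on a saturated ring carbon brings a 17-fold higher number from compound 2 to compound 4 (1.23 log units; beyond the scatter) and so counts as a large step. This ring carbon, two ring bonds from the ring nitrogen, is therefore sensitive to what it carries, and compound 2 with trifluoromethyl needs far less compound for its effect. Nothing in the data shown accounts for the size of this step. Going by these compounds, whether a smaller group on this carbon, such as methyl or a single fluorine, would hold the effect stays open. So does whether adding trifluoromethyl would act alike on the core of compound 3.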